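Swapping Methyl for Chloro on the Benzyl Arm

This account rests on a few compounds, and the source may have more. Where it says the series, first, only, none or still open, it means among the compounds named here.

Compound 1 `Cc1ccc(Cn2c(=O)n(C[C@H](C)C(=O)O)c(=O)[nH]/c2=N\c2ccc(OC(C)C)c(Cl)c2)cc1` gives 0.014 in an ADME assay on the whole organism (plasma, Rattus norvegicus) for protein binding, using cassette dosing, at a dose of 1 mg/kg (a higher number here means a larger unbound share of the compound, a lower number a smaller unbound share), the highest of the three numbers shown. Compound 3 `C[C@@H](Cn1c(=O)[nH]/c(=N\c2ccc(Oc3ccccn3)cc2)n(Cc2ccc(Cl)cc2)c1=O)C(=O)O` gives 0.01, a gap within the scatter, while compound 2 `C[C@@H](Cn1c(=O)[nH]/c(=N\c2ccc(Oc3nccs3)cc2)n(Cc2ccc(Cl)cc2)c1=O)C(=O)O` gives 0.006, a gap beyond it. Within the data shown here, the only measured step, a 1.7-fold higher number from compound 2 to compound 3 (0.22 log units; within the scatter), concerns the aryl ether and not the benzyl arm. Compound 4 `CC(C)Oc1ccc(/N=c2\[nH]c(=O)n(C[C@H](C)C(=O)O)c(=O)n2Cc2ccc(Cl)cc2)cc1Cl` differs from compound 1 by chloro in place of methyl on an aromatic carbon, giving it the 4-chlorobenzyl that compounds 2 and 3 already carry. Among the measured compounds shown here, no measured pair isolates this change, so no step beyond the scatter is expected in this assay. For compound 4 the expected value is 0.012, between 0.006 and 0.025, a step of a 1.2-fold lower number from compound 1 to compound 4 (0.07 log units; within the scatter).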

Compound 4, unbound fraction: 0.003
Compound 4: middle estimate off by 4.0-fold (0.60 log units), on the high side; the measured number lies below the stated range.
By their numbers in this assay, from the lowest: compounds 4, 2, 3 and 1 (each within the scatter of the next, the first and the last beyond it).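

In this assay the change from 4-methylbenzyl to 4-chlorobenzyl gives a 4.7-fold lower number from compound 1 to compound 4 (0.67 log units; beyond the scatter) and so shows that one atom swapped on the benzyl arm can shift the unbound share beyond the scatter. Among these compounds, the only earlier step concerned the aryl ether and stayed within the scatter, so this is the first sign that this position matters. No measurement shown here explains the shift.

Going by these compounds, whether the step would keep its size with a different aryl ether remains open. So does the outcome with a fluoro or a methoxy at this same place on the benzyl ring.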